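Replacing the Aryl Chlorine with Two Methyls in Compound 4

The source may report more compounds than this note shows. Statements on the series, on what has been measured and on what is new or still open speak of the compounds shown alone.

Compound 1 `Cc1oc(-c2ccccc2Cl)nc1CN1CCC(C(=O)NCCCN2C[C@H](C)C[C@H](C)C2)CC1` stands second highest of the three numbers in a physicochemical assay for permeability, using PAMPA; on this read-out higher numbers stand for higher permeability and lower numbers for lower permeability: compound 1 gives 352 10^-6 cm/s, compound 2 `Cc1ccccc1-c1nc(CN2CCC(C(=O)NCCCCN3C[C@H](C)C[C@H](C)C3)CC2)c(C)o1` gives 288 10^-6 cm/s, which is within the scatter of it, and compound 3 `CCCN(CCC)CCNC(=O)C1CCN(Cc2nc(-c3ccccc3C)oc2C)CC1` gives 913 10^-6 cm/s, beyond it. Among the compounds with values here, the one single-place step measured, a 3.2-fold higher number from compound 2 to compound 3 (0.50 log units; beyond the scatter), concerns the amine end of the chain and leaves the aromatic substituent untouched. Compound 4 `Cc1cccc(C)c1-c1nc(CN2CCC(C(=O)NCCCN3C[C@H](C)C[C@H](C)C3)CC2)c(C)o1` differs from compound 1 by 2,6-dimethylphenyl in place of 2-chlorophenyl on an aromatic carbon. Within the data shown here, no measured step speaks to this change; compound 2, which carries a 2-methylphenyl group together with a longer chain, lies close to compound 1. Compound 4 is therefore expected to show a step of a 1.1-fold higher number from compound 1 to compound 4 (0.03 log units; within the scatter), nothing beyond the scatter, with an estimate of 380 10^-6 cm/s ranging from 200 10^-6 cm/s to 720 10^-6 cm/s.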

Compound 4, apparent permeability: 254 10^-6 cm/s
Compound 4: the middle estimate sits 1.5-fold (0.17 log units) above what was measured; the range from low to high includes it.
By their numbers in this assay, from the lowest: compounds 4, 2 and 1 (each within the scatter of the next); then compound 3.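

In this assay (this assay), 2,6-dimethylphenyl in place of 2-chlorophenyl on an aromatic carbon gives a 1.4-fold lower number from compound 1 to compound 4 (0.14 log units; within the scatter). Within the data shown here, this is the first single-place step at this position, next to the ring nitrogen and next to the ring oxygen, and it shows that this exchange of aryl groups stays within the scatter. Nothing available explains this result. Still open, from the compounds shown here alone, is whether a plain phenyl, or a phenyl carrying an amine or a carboxylic acid, would also stay within the scatter of compound 1.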